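The source may hold more compounds than are shown below. What is called first, only, known or untested is meant among the compounds shown, and "the series" means these compounds.

Measured compounds:
Compound 1 `CCN(CC)C(=O)Cc1c(-c2ccc(OC3CCCC3)cc2)nn2c(C)cc(C)nc12` — in an assay on isolated protein (kidney, strain Wistar) for displacement of a labelled ligand from Translocator protein (Rattus norvegicus), read by scintillation counting, with a stated time of 90 min (on this read-out lower numbers stand for stronger inhibition and higher numbers for weaker inhibition), compound 1 gives 1.5 nM.
Compound 2 `CCN(CC)C(=O)Cc1c(-c2ccc(OCC3CC3)cc2)nn2c(C)cc(C)nc12` — in this assay compound 2 gives 3 nM.
Compound 3 `CCN(CC)C(=O)Cc1c(-c2ccc(OCC3CCCC3)cc2)nn2c(C)cc(C)nc12` — in this assay compound 3 gives 2.1 nM.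

All three compounds share one core and differ only in the group on the oxygen on the aromatic ring. The number for compound 3 lies between those of its two companions, but neither gap is meaningful: a 1.4-fold higher number from compound 1 to compound 3 (0.15 log units; within the scatter) and a 1.4-fold lower number from compound 2 to compound 3 (0.15 log units; within the scatter) both fall inside the usual scatter, as does a 2.0-fold higher number from compound 1 to compound 2 (0.30 log units; within the scatter). In other words, changing the size or shape of this ring-bearing group has so far left this assay essentially unmoved.

Compound 4 `CCN(CC)C(=O)Cc1c(-c2ccc(OCC3CCCCC3)cc2)nn2c(C)cc(C)nc12` is the next member of this set. The change from compound 3 is cyclohexyl in place of cyclopentyl on a saturated chain carbon bound to an oxygen on an aromatic ring. The most closely related step is a 1.4-fold lower number from compound 2 to compound 3 (0.15 log units; within the scatter), a change of ring size on the same carbon, and it stayed within the scatter. On that basis no step beyond the scatter is expected in this assay, in either direction, and the expected step of a 1.0-fold higher number from compound 3 to compound 4 (0.02 log units; within the scatter) reflects this. Compound 4 is therefore estimated at 2.2 nM, with a range from 1 nM to 5 nM.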

Compound 4, inhibition constant: 3.6 nM
Compound 4: the middle estimate sits 1.6-fold (0.21 log units) below what was measured; the measured number falls inside the stated range.
By their numbers in this assay, from the lowest: compounds 1, 3, 2 and 4 (each within the scatter of the next, the first and the last beyond it).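

Moving up one ring size on the saturated chain carbon bound to an oxygen on an aromatic ring still leaves this assay within the scatter: cyclohexyl in place of cyclopentyl gives (a 1.7-fold higher number from compound 3 to compound 4 (0.23 log units; within the scatter)) and cyclohexyl in place of cyclopropyl gives (a 1.2-fold higher number from compound 2 to compound 4 (0.08 log units; within the scatter)). Cyclopropyl, cyclopentyl and cyclohexyl on that carbon therefore cannot be told apart. Going by these compounds alone, the first step beyond the scatter in this set, though a modest one, appears when cyclopentyl on the oxygen gives way to cyclohexylmethyl (a 2.4-fold higher number from compound 1 to compound 4 (0.38 log units; beyond the scatter)), and nothing measured here accounts for it.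

From the compounds shown here alone, what an open chain such as hexyl on the same carbon would do remains open. So does the effect of a ring carrying an amine, such as piperidinyl, or an aromatic ring such as phenyl.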